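The source may report more compounds than this note shows. Statements on the series, on what has been measured and on what is new or still open speak of the compounds shown alone.

In an ADME assay on L6 cells (Rattus norvegicus) for cytotoxicity (a higher number here means a weaker inhibitor, a lower number a stronger inhibitor), two compounds have been measured so far. Compound 1 (`CCN(CC)CCC(=O)OC1CC2(N(C)C)CC(c3ccccc3)C1C(c1ccccc1)C2`) gives 23600 nM and compound 2 (`CN(C)C12CC(OC(=O)CN3CCC(O)CC3)C(C(c3ccccc3)C1)C(c1ccccc1)C2`) gives 102000 nM as the higher of the two numbers, so compound 2 is the weaker inhibitor of this pair.

Compound 3 (`CN(C)C12CC(OC(=O)CCN3CCC(O)CC3)C(C(c3ccccc3)C1)C(c1ccccc1)C2`) differs from compound 2 in one place, where (4-hydroxypiperidin-1-yl)methyl stands in place of 4-hydroxypiperidin-1-yl on a saturated chain carbon bound to a carbonyl carbon ((4-hydroxypiperidin-1-yl)methyl in place of 4-hydroxypiperidin-1-yl on a saturated chain carbon bound to a carbonyl carbon).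

Among the compounds with values here, only one measured step touches this place, and a 4.3-fold higher number from compound 1 to compound 2 (0.64 log units; beyond the scatter) is a modest one. Within the data shown here, that step swapped a whole group, (diethylamino)methyl for 4-hydroxypiperidin-1-yl, so it cannot show what the added methyl does alone, and no measured step changes only that.

The new change brings back a methyl link, so it may undo a part of that step. A small move toward a lower number is expected in this assay and it may not clear the usual scatter. The expected move is a 1.9-fold lower number from compound 2 to compound 3 (0.27 log units; within the scatter) as a rough guide. For compound 3 the estimated value is 55000 nM with a range from 22000 nM to 120000 nM as its likely span.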

Compound 3, half-maximal inhibitory concentration: 89200 nM
The estimate for compound 3 lay 1.6-fold (0.21 log units) below the measured number; the measured number falls inside the stated range.
By their numbers in this assay, from the lowest: compound 1; then compounds 3 and 2 (each within the scatter of the next).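

In this assay, going from (4-hydroxypiperidin-1-yl)methyl to 2-(4-hydroxypiperidin-1-yl)ethyl gives a 1.1-fold lower number from compound 2 to compound 3 (0.06 log units; within the scatter), so with this amine in place, the added methyl link produces no difference that can be told apart from the scatter. Within the data shown here, compound 3 also carries the same chain length as compound 1, which separates the amine from the chain for the first time: 4-hydroxypiperidin-1-yl in place of diethylamino alone gives a 3.8-fold higher number from compound 1 to compound 3 (0.58 log units; beyond the scatter), close in size to the earlier mixed change of a 4.3-fold higher number from compound 1 to compound 2 (0.64 log units; beyond the scatter), so across these three compounds the gap follows the amine rather than the chain length. Nothing available here gives a reason for these numbers.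

Still open, from the compounds shown here alone, is whether chain length would matter with a different amine, since (diethylamino)methyl on the carbonyl carbon would be needed to test the chain change with diethylamino as well. It is also unclear whether the hydroxyl or the ring of 4-hydroxypiperidin-1-yl goes with the higher number, a question that plain piperidin-1-yl could help to settle.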